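This account rests on a few compounds, and the source may have more. Where it says the series, first, only, none or still open, it means among the compounds named here.

Compound 1 `CC1(C)CNC(=O)c2sc(Nc3ccc(I)cc3F)c(C(N)=O)c2C1` and compound 2 `CC(C)(N)CNC(=O)c1c(Nc2ccc(I)cc2F)sc2c1CC(C)(C)CNC2=O` share a core and differ only on an amide-type nitrogen. In a functional assay on HT-29 cells (Homo sapiens) for antiproliferative activity (on this read-out higher numbers stand for weaker inhibition and lower numbers for stronger inhibition), compound 1 gives 158 nM, and compound 2 gives 79 nM. Within the data shown here, the single measured step, a 2.0-fold lower number from compound 1 to compound 2 (0.30 log units; within the scatter), is therefore the only guide to how that nitrogen tolerates substitution, and it shows no change beyond the scatter. Compound 2 thus carries the lowest number of the two, with compound 1 lying within the scatter of it, so no order between them can be claimed.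

Compound 3 `CC1(C)CNC(=O)c2sc(Nc3ccc(I)cc3F)c(C(=O)N[C@@H]3CCCNC3)c2C1` is not yet measured. It differs from compound 2 by piperidin-3-yl in place of 2-amino-2-methylpropyl on an amide-type nitrogen. Among the measured compounds shown here, the group that leaves and the group that enters each bring one hydrogen-bond donor and one hydrogen-bond acceptor, and the only comparable step, the substitution on the same nitrogen from compound 1 to compound 2, was within the scatter. For the measured compounds named here, no step in the data addresses a ring in this position. Compound 3 is therefore expected to stay close to compound 2, with a step of a 1.1-fold lower number from compound 2 to compound 3 (0.02 log units; within the scatter) estimated in this assay. The estimate for compound 3 is 75 nM, expected to lie between 25 nM and 230 nM.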

Compound 3, half-maximal inhibitory concentration: 91 nM
Estimate against measurement, compound 3: 1.2-fold (0.08 log units) below; measured number inside the range.
By their numbers in this assay, from the lowest: compounds 2, 3 and 1 (each within the scatter of the next).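

In this assay, the amide-type nitrogen now carries a ring as well as an open chain: piperidin-3-yl in place of 2-amino-2-methylpropyl gives a 1.2-fold higher number from compound 2 to compound 3 (0.06 log units; within the scatter) and so brings no difference that can be claimed, even though the entering group adds one six-membered non-aromatic ring and a defined stereocentre. Measured against the amide hydrogen of compound 1, the same group gives a 1.7-fold lower number from compound 1 to compound 3 (0.24 log units; within the scatter), so neither the open chain nor the ring separates from the unsubstituted amide, and this nitrogen has so far accepted all three without a readable change. Nothing at hand bears on why the numbers stay so close.

The compounds shown leave open whether the other configuration at the stereocentre of piperidin-3-yl would read the same. They also leave open whether the nitrogen inside the entering and leaving groups matters at all, a question that a cyclohexyl group, with the ring but no nitrogen, or a carboxylic acid on a longer chain in the same place would address.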